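Methoxy to nitro on the aromatic ring: working notes

The compounds below may be only part of what the source reports. "The series", "measured", "known", "first", "only" and "open" are said of these compounds alone.

Values in a functional assay on U-251 cells (Homo sapiens) for inhibition, read by sulforhodamine B assay, with a stated time of 48 h; on this read-out higher numbers stand for weaker inhibition of growth and lower numbers for stronger inhibition of growth:
compound 1 `CC(C)(C)NCc1c(C(=O)O)nn(-c2ccccc2)c1-c1ccc(Br)cc1`: 126000 nM
compound 2 `CC(C)(C)NCc1c(C(=O)O)nn(-c2ccccc2)c1-c1ccccc1`: > 716000 nM, a limit
compound 3 `COc1ccc(-c2c(CNC(C)(C)C)c(C(=O)O)nn2-c2ccccc2)cc1`: > 659000 nM, a limit

Compound 3 stands at > 659000 nM, which is a limit and not a number. Among the measured compounds shown here, only compound 1 has a measured number so far.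

The next change gives compound 4 `CC(C)(C)NCc1c(C(=O)O)nn(-c2ccccc2)c1-c1ccc([N+](=O)[O-])cc1`, with nitro in place of methoxy on an aromatic carbon, para to a large group: nitro in place of methoxy on an aromatic carbon.

For the measured compounds named here, two measured steps bear on this position. Hydrogen in place of bromo gives an at least 5.6-fold higher number from compound 1 to compound 2 (0.75 log units; beyond the scatter), and methoxy in place of bromo gives an at least 5.2-fold higher number from compound 1 to compound 3 (0.71 log units; beyond the scatter). Both lie beyond the scatter. Methoxy in place of hydrogen gives a step that the two limits leave unreadable from compound 2 to compound 3.

Going by the values given here, the group at this position can therefore shift the read-out, but no measured compound carries nitro. A modest move towards a lower number in this assay is expected, with compound 1 at 126000 nM as the nearest reading. Another limit remains quite possible. The expected change is an at least 2.1-fold lower number from compound 3 to compound 4 (0.34 log units; beyond the scatter). For compound 4 the estimated value is 300000 nM, with an expected range of 90000 nM to 800000 nM.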

Compound 4, concentration for 50% growth inhibition: > 634000 nM
Compound 4 ended at the assay's limit; the forecaster's own chance of this, stated with the estimate: 45%; middle value at least 2.1-fold (0.32 log units) from the limit.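

In this assay compound 4 gives a limit and not a number: the limit of > 634000 nM in this assay, at which 1 of the 4 values shown sits. Nitro in place of bromo gives an at least 5.0-fold higher number from compound 1 to compound 4 (0.70 log units; beyond the scatter), so all three replacements of bromo shown at this position (hydrogen, methoxy and nitro) now move the read-out beyond the scatter towards weaker inhibition of growth, and bromo remains the only group here with a measured number. The steps linking compound 4 with compound 2 and compound 3 cannot be read, and with the earlier step between compound 2 and compound 3 this leaves no order among hydrogen, methoxy and nitro.

The compounds shown leave open whether chloro or iodo in the same place would also give a measured number. As far as these compounds go, it is also open whether an amine or a longer chain there would bring the read-out within the measurable range.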